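The source may hold more compounds than are shown below. What is called first, only, known or untested is meant among the compounds shown, and "the series" means these compounds.

Measured in a functional assay on A549 cells (Homo sapiens) for inhibition, read by MTT assay, with a stated time of 72 h; on this read-out lower numbers stand for stronger inhibition and higher numbers for weaker inhibition:
- compound 1 `COc1ccccc1-c1csc2cnc(Nc3ccc(NC(=O)[C@H]4CCCNC4)cc3)nc12`: 500 nM
- compound 2 `COc1ccccc1-c1csc2cnc(Nc3ccc(NC(=O)CN)cc3)nc12`: 1950 nM

Of these two, compound 2 has the higher number, 1950 nM. Compound 3 `CNC(=O)c1ccc(Nc2ncc3scc(-c4ccccc4OC)c3n2)cc1` is still unmeasured. The change to it is methylcarbamoyl in place of ((aminomethyl)carbonyl)amino on an aromatic carbon, para to a large group.

Going by the values given here, only one measured step is available: a 3.9-fold higher number from compound 1 to compound 2 (0.59 log units; beyond the scatter), with aminomethyl in place of piperidin-3-yl on a carbonyl carbon. It bears only loosely on the new change, which replaces the whole substituent rather than the group on its carbonyl carbon. Among the compounds with values here, a further modest rise in the number is therefore expected, no larger than that step, though it may stay within the scatter.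

The step expected in this assay is a 1.4-fold higher number from compound 2 to compound 3 (0.16 log units; within the scatter). Compound 3 is estimated at 2800 nM, with an expected range of 900 nM to 8500 nM.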

Compound 3, half-maximal inhibitory concentration: 310 nM
Beside the measured number, compound 3's estimate is 9.0-fold (0.96 log units) above it; measured number outside the range, below it.
By their numbers in this assay, from the lowest: compounds 3 and 1 (each within the scatter of the next); then compound 2.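

In this assay, methylcarbamoyl on this aromatic carbon, para to a large group, gives a 6.3-fold lower number from compound 2 to compound 3 (0.80 log units; beyond the scatter) and so does better here than ((aminomethyl)carbonyl)amino. The amine carried by compound 1 and compound 2 is therefore not required at this position for activity in this range: without it, the comparison with the piperidine-bearing compound shows a 1.6-fold lower number from compound 1 to compound 3 (0.21 log units; within the scatter) and the two cannot be told apart. No supporting data bear on why the change acts as it does.

The compounds shown do not separate the loss of the amine from the switch to a carbonyl attached directly to the aromatic carbon, a question that an acetylamino group here would address. As far as these compounds go, how far this position extends beyond methylcarbamoyl also remains open, for example with ethylcarbamoyl or a carboxylic acid.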